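The source may report more compounds than this note shows. Statements on the series, on what has been measured and on what is new or still open speak of the compounds shown alone.

Measured in an ADME assay on PBMC cells (Homo sapiens) for cytotoxicity, with a stated time of 5 days; on this read-out lower numbers stand for stronger inhibition and higher numbers for weaker inhibition:
- compound 1 `[N-]=[N+]=N[C@H]1C[C@H](n2cnc3c(NC4CC4)nc(Cl)nc32)O[C@@H]1CO`: 35300 nM
- compound 2 `CN(C)c1nc(N)nc2c1ncn2[C@H]1C[C@H](N=[N+]=[N-])[C@@H](CO)O1`: > 100000 nM, a limit
- compound 3 `CNc1nc(Cl)nc2c1ncn2[C@H]1C[C@H](N=[N+]=[N-])[C@@H](CO)O1`: > 100000 nM, a limit

Compound 3 has no number, only (the limit of > 100000 nM in this assay, at which 2 of the 3 values shown sit). Compound 4 `CN(C)c1nc(Cl)nc2c1ncn2[C@H]1C[C@H](N=[N+]=[N-])[C@@H](CO)O1` differs from it by methyl in place of hydrogen on a nitrogen on an aromatic ring, or methylamino to dimethylamino.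

Within the data shown here, the one measured step on that nitrogen is an at least 2.8-fold higher number from compound 1 to compound 3 (0.45 log units; beyond the scatter). It exchanges a different group, so it bears only loosely on this change. Compound 2 also carries dimethylamino but differs elsewhere, and its result is a limit, > 100000 nM.

Among the measured compounds shown here, with compound 1 as the only numeric guide, a small move towards lower numbers is expected in this assay, namely an at least 1.2-fold lower number from compound 3 to compound 4 (0.09 log units; that floor lies within the scatter). Compound 4 is estimated at 80000 nM, with an expected range of 25000 nM to 200000 nM.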

Compound 4, half-maximal inhibitory concentration: > 100000 nM
Compound 4: only a limit was reported; the forecaster's own chance of this, stated with the estimate: 60%; at least 1.2-fold (0.09 log units) between middle value and limit.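

Methyl in place of hydrogen on this nitrogen does not bring the number in this assay into the readable range, so methylamino to dimethylamino shows no readable change, and the steps from compound 3 and from compound 2 to compound 4 cannot be read. Dimethylamino in place of cyclopropylamino gives an at least 2.8-fold higher number from compound 1 to compound 4 (0.45 log units; beyond the scatter). Compound 1 is now the only compound shown with a number, and the others share one limit: the limit of > 100000 nM in this assay, at which 3 of the 4 values shown sit.

Going by these compounds, whether a longer chain such as propylamino or a cyclic amine such as morpholine would also give a number stays open. On these data alone, how far compound 2, compound 3 and compound 4 lie past that limit also stays open.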